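Amino in place of fluoro at the high end

A few compounds are considered here, and "the series" means these few. Any claim that something is new, unique, unknown or untested is made for them only; others in the source may bear on it.

In a functional assay on cells (Endothelial cell, Bos taurus) for antiproliferative activity (on this read-out lower numbers stand for stronger inhibition and higher numbers for weaker inhibition), compound 1 `COc1ccc(/C=C(\F)c2cc(OC)c(OC)c(OC)c2)cc1O` gives 13000 nM as its number, compound 2 `COc1ccc(/C=C\c2cc(OC)c(OC)c(OC)c2)cc1[N+](=O)[O-]` gives 135000 nM as its number and compound 3 `COc1ccc(/C(F)=C/c2cc(OC)c(OC)c(OC)c2)cc1F` gives 610000 nM as the highest of the three. Compound 3 therefore stands at the weak end of the set, with both other numbers lower by more than the scatter.

Compound 4 `COc1ccc(/C(F)=C/c2cc(OC)c(OC)c(OC)c2)cc1N` comes from compound 3 by a single change: amino in place of fluoro on an aromatic carbon with amino in place of fluoro on an aromatic carbon, ortho to a methoxy group and meta to a large group. Among the measured compounds shown here, no two measured compounds differ in one place only, so the series offers no direct precedent for this change. The expectation rests on the spread alone: compound 1 at 13000 nM and compound 2 at 135000 nM both lie well under compound 3, whose number marks the top of the set so far. In this assay the expected change is a 20-fold lower number from compound 3 to compound 4 (1.31 log units; beyond the scatter) towards stronger inhibition, beyond the scatter but with low confidence. For compound 4 the estimate is 30000 nM with an expected range from 3000 nM to 200000 nM as a working figure.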

Compound 4, half-maximal inhibitory concentration: 111000 nM
Compound 4: middle estimate off by 3.7-fold (0.57 log units), on the low side; low and high end bracket the measured number.
By their numbers in this assay, from the lowest: compound 1; then compounds 4 and 2 (each within the scatter of the next); then compound 3.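

Among the compounds shown here, this is the first single-place step: on the aromatic carbon ortho to a methoxy group and meta to a large group, amino in place of fluoro in this assay gives a 5.5-fold lower number from compound 3 to compound 4 (0.74 log units; beyond the scatter), modest in size but beyond the scatter. The position is therefore not indifferent to its substituent, and exchanging a fluoro with no hydrogen-bond donors or acceptors for an amino with one of each moves the number towards stronger inhibition. No measured property of either group accompanies the step, so it stands as an observation with no established cause.

On these data alone, whether the step is specific to amino remains open; an acetamide or a dimethylamino group on the same aromatic carbon would test whether the shift survives when the amino hydrogens are replaced. Also open is whether the step carries over to the arrangements of the core seen in compound 1 and compound 2; neither has a partner differing in one place among the compounds shown.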